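From a Carboxy Group to a Carbamoyl Group

A few compounds are considered here, and "the series" means these few. Any claim that something is new, unique, unknown or untested is made for them only; others in the source may bear on it.

Measured compounds:
Compound 1, `CNS(=O)(=O)c1ccc(-c2cnc(N)c(-c3ccc(OC)nc3)c2)cc1`, gives 3.02 h in an in vitro ADME assay on microsomes from liver (Homo sapiens) for metabolic stability; on this read-out higher numbers stand for a longer-lived compound and lower numbers for a shorter-lived compound.
Compound 2, `COc1ccc(-c2cc(-c3ccc(C(=O)O)cc3)cnc2N)cn1`, gives > 4.16 h in this assay, a limit of the assay rather than a number.

Compound 2 thus stands at the limit of > 4.16 h in this assay, at which 1 of the 2 values shown sits. For the measured compounds named here, the one measured step that leads to it is an at least 1.3-fold higher number from compound 1 to compound 2 (0.13 log units; that floor lies within the scatter). Compound 3, `COc1ccc(-c2cc(-c3ccc(C(N)=O)cc3)cnc2N)cn1`, differs from compound 2 by amino in place of hydroxy on a carbonyl carbon, the same difference reading, cut one bond further out, as carboxy to carbamoyl. Going by the values given here, the single measured step concerns the group on the aromatic carbon, not the carbonyl carbon now altered, and its own floor lies within the scatter; no measured step gives the size of a change from carboxy to carbamoyl here. The step from compound 2 to compound 3 in this assay is therefore expected to be small, an at least 1.1-fold lower number from compound 2 to compound 3 (0.07 log units; that floor lies within the scatter), with no clear direction beyond the scatter. Compound 3 is estimated at 3.5 h in this assay, with a range from 1.5 h to 4.16 h.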

Compound 3, half-life: > 4.16 h
Compound 3: only a limit was reported; the forecaster's own chance of this, stated with the estimate: 45%; middle value at least 1.1-fold (0.07 log units) from the limit.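

In this assay compound 3 gives > 4.16 h as a limit of the assay and not a number. For the compounds shown here, with carbamoyl on this aromatic carbon, the change from the methylsulfamoyl group reads as an at least 1.3-fold higher number from compound 1 to compound 3 (0.13 log units; that floor lies within the scatter) and so stays no firmer than the step seen for the carboxy group. The change from carboxy to carbamoyl itself cannot be read, and the amide now shares the limit with the acid: (the limit of > 4.16 h in this assay, at which 2 of the 3 values shown sit).

Going by these compounds, how far compound 2 and compound 3 lie past that limit stays open, so no order between carboxy and carbamoyl can be given. On these data alone, it is also open whether a methylcarbamoyl group or a nitrile on the same aromatic carbon would reach the same limit.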